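This account rests on a few compounds, and the source may have more. Where it says the series, first, only, none or still open, it means among the compounds named here.

Compound 3 `COc1ccccc1NC(=O)CC1CCc2cc(OC)c(OC)cc21` gives 16% in a functional assay on the whole organism (strain Wistar) for inhibition, with Rattus norvegicus as the target, read by paw edema, with a stated time of 2 h, at a dose of 100 mg/kg (on this read-out lower numbers stand for less inhibition and higher numbers for more inhibition at the one dose given (going by the name of the read-out)), the lowest of the three numbers, though compound 2 `COc1cc2c(cc1OC)C(CC(=O)Nc1ccccc1C)CC2` with 18% lies within the scatter of it, while compound 1 `COc1cc2c(cc1OC)C(CC(=O)Nc1ccc(Cl)cc1)CC2` gives 63%. Two steps were large: a number 45 percentage points lower from compound 1 to compound 2 (beyond the scatter) and a number 47 percentage points lower from compound 1 to compound 3 (beyond the scatter), each replacing 4-chlorophenyl on the amide-type nitrogen. The third, a number 2 percentage points lower from compound 2 to compound 3 (within the scatter), fell within the scatter. Compound 4 `COc1cc2c(cc1OC)C(CC(=O)Nc1ccccn1)CC2` differs from compound 3 by pyridin-2-yl in place of 2-methoxyphenyl on an amide-type nitrogen. For the measured compounds named here, no measured step exchanges 2-methoxyphenyl for pyridin-2-yl, so the large steps from compound 1 only set a scale for how far this series can move. Compound 4 is expected to show a number 14 percentage points higher from compound 3 to compound 4 (beyond the scatter), a modest rise. The estimate for compound 4 is 30%, between 10% and 55%.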

Compound 4, a percentage reported as inhibition, in the whole organism at one dose (the size of the read-out at that dose, not a potency): 32%
Compound 4: middle estimate off by 2 percentage points, on the low side; the range from low to high includes it.
By their numbers in this assay, from the lowest: compounds 3 and 2 (each within the scatter of the next); then compound 4; then compound 1.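

Pyridin-2-yl on the amide-type nitrogen sets compound 4 apart from both low compounds in this assay, with a number 16 percentage points higher from compound 3 to compound 4 (beyond the scatter) and a number 14 percentage points higher from compound 2 to compound 4 (beyond the scatter). It does not reach the level of the 4-chlorophenyl group, with a number 31 percentage points lower from compound 1 to compound 4 (beyond the scatter), so this position also allows an intermediate read-out. Nothing available here explains these differences. Open remains how plain phenyl or cyclohexyl would read on this nitrogen. Plain phenyl would help separate the contribution of the ring nitrogen in pyridin-2-yl from the absence of the methoxy or methyl group.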